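Thiophen-2-yl for 2-methoxyphenyl on the chain of compound 1

The compounds below may be only part of what the source reports. "The series", "measured", "known", "first", "only" and "open" are said of these compounds alone.

Working notes on a short series sharing one core. Among the measured compounds shown here, compound 1 `COc1ccccc1/C=C/C(=O)/C=C/c1ccc(OCc2cn(CCCCCOc3cc(=O)oc4ccccc34)nn2)c(OC)c1` is the weakest of the three measured members: in a functional assay on COLO 205 cells (Homo sapiens) for inhibition, read by sulforhodamine B assay, with a stated time of 48 h, tested at 50 uM (a lower number here means less inhibition of growth, a higher number more inhibition of growth at the concentration tested), compound 1 gives 30%. Compound 2 `COc1cc(/C=C/C(=O)/C=C/c2cc(OC)c(OC)c(OC)c2)ccc1OCc1cn(CCCOc2cc(=O)oc3ccccc23)nn1` gives 74%, and compound 3 `COc1ccc(/C=C/C(=O)/C=C/c2ccc(OCc3cn(CCOc4cc(=O)oc5ccccc45)nn3)c(OC)c2)cc1OC` gives 80%; both lie beyond the scatter above compound 1, which thus stands lowest. For the measured compounds named here, no single-point step between measured compounds is available, so nothing measured tells how a change of the terminal aryl group alone moves the number. Compound 4 `COc1cc(/C=C/C(=O)/C=C/c2cccs2)ccc1OCc1cn(CCCCCOc2cc(=O)oc3ccccc23)nn1` differs from compound 1 in one place: thiophen-2-yl in place of 2-methoxyphenyl on a double-bonded chain carbon bound to a double-bonded chain carbon. The expected step is small, likely not beyond the scatter, leaning slightly upward: a number 8 percentage points higher from compound 1 to compound 4 (within the scatter). Compound 4 is expected to give about 38%, within 15% to 65%.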

Compound 4, percent growth inhibition at one concentration: 30%
Compound 4: middle estimate off by 8 percentage points, on the high side; the range from low to high includes it.
By their numbers in this assay, from the lowest: compounds 1 and 4 (each within the scatter of the next); then compounds 2 and 3 (each within the scatter of the next).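

In this assay the series gains its first single-place step, and it reads no change at the digits printed from compound 1 to compound 4 (within the scatter) for thiophen-2-yl in place of 2-methoxyphenyl. At this place on the chain, then, a six-membered aromatic ring of carbon only and a five-membered aromatic ring with 1 hetero atom are not told apart by this read-out. Nothing at hand bears on why the number stays put. Open, going by these compounds, is whether a pyridin-3-yl or a 4-(dimethylamino)phenyl group here would shift the number, and whether the same step holds on the chain of compound 3.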